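The source may report more compounds than this note shows. Statements on the series, on what has been measured and on what is new or still open speak of the compounds shown alone.

Of the compounds shown here, three have been measured in a functional assay on SiHa cells (Homo sapiens) for inhibition, read by CCK-8 assay, with a stated time of 72 h, tested at 1 uM (on this read-out higher numbers stand for more inhibition of growth at the one concentration tested and lower numbers for less inhibition of growth), so far.

Compound 1 `CN(C)C(=O)c1cc2cnc(Nc3ccc(NC(=O)C4(C(=O)Nc5cccc(F)c5)CC4)cc3)nc2n1C1CCCC1` gives 29.7% in this read-out
Compound 2 `CN(C)C(=O)c1cc2cnc(Nc3ccc(NC(=O)C4(C(=O)Nc5ccc(Cl)c(C(F)(F)F)c5)CC4)cc3)nc2n1C1CCCC1` gives -11.2% in this read-out
Compound 3 `Cc1ccc(NC(=O)C2(C(=O)Nc3ccc(Nc4ncc5cc(C(=O)N(C)C)n(C6CCCC6)c5n4)cc3)CC2)cc1` gives 37% in this read-out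

The measurements show a number 7.3 percentage points higher from compound 1 to compound 3 (within the scatter) but a number 48.2 percentage points higher from compound 2 to compound 3 (beyond the scatter) on the same scale. Compound 3 thus stands with compound 1 at the upper end of this small set, while compound 2 lies apart at the lower end.

The next compound, compound 4 `CN(C)C(=O)c1cc2cnc(Nc3ccc(NC(=O)C4(C(=O)Nc5ccccc5)CC4)cc3)nc2n1C1CCCC1`, departs from compound 3 at one place: hydrogen in place of methyl on an aromatic carbon and so 4-methylphenyl becomes phenyl. Within the data shown here, no measured pair isolates this exact change. The closest evidence comes from swaps of the aryl group on the amide-type nitrogen. Among these, a number 7.3 percentage points higher from compound 1 to compound 3 (within the scatter) is the one step between two groups of the kind at issue here. The large steps, a number 40.9 percentage points lower from compound 1 to compound 2 (beyond the scatter) and a number 48.2 percentage points higher from compound 2 to compound 3 (beyond the scatter), both involve 4-chloro-3-(trifluoromethyl)phenyl, which plays no part in this change. The expected step in this assay is therefore small, estimated as a number 6 percentage points lower from compound 3 to compound 4 (within the scatter) and not expected to pass beyond the scatter. For compound 4 the estimated value is 31% with an expected range from 15% to 47% as the likely span.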

Compound 4, percent growth inhibition at one concentration: 58%
The estimate for compound 4 lay 27 percentage points below the measured number; measured number outside the range, above it.
By their numbers in this assay, from the lowest: compound 2; then compounds 1 and 3 (each within the scatter of the next); then compound 4.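

In this assay, removing the methyl group para to a large group gave a number 21 percentage points higher from compound 3 to compound 4 (beyond the scatter), so the bare phenyl ring separates from 4-methylphenyl in a way that the earlier aryl swaps did not predict. The same holds against the other two rings, with a number 28.3 percentage points higher from compound 1 to compound 4 (beyond the scatter) for hydrogen in place of fluoro and a number 69.2 percentage points higher from compound 2 to compound 4 (beyond the scatter) for phenyl in place of 4-chloro-3-(trifluoromethyl)phenyl. Among these four compounds, each of the three substituted rings therefore gives a lower number than the unsubstituted ring, and none goes against this, although 3-fluorophenyl and 4-methylphenyl stay within the scatter of each other. Nothing shown here accounts for this rise on losing the methyl group.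

The compounds shown leave open whether the lower numbers follow the place of a substituent on this ring or its identity, as fluoro and methyl sit at different places in compound 1 and compound 3. They also leave open how a methoxy group, an amine or a carboxylic acid on this ring would compare with the bare phenyl of compound 4.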